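A few compounds are considered here, and "the series" means these few. Any claim that something is new, unique, unknown or untested is made for them only; others in the source may bear on it.

Of the compounds shown here, three of the shared core have so far been tested in an ADME assay on BJ cells (Homo sapiens) for antiproliferative activity, with a stated time of 72 h; on this read-out higher numbers stand for an effect only at larger amounts of compound and lower numbers for an effect already at smaller amounts. Compound 1 `COc1ccc(-c2[nH]c3cc(OC)cc(OC)c3c(=O)c2I)cc1` gives in this assay > 86200 nM, which is a limit of the assay and not a number. Compound 2 `COc1ccc(-c2cc(=O)c3c(OC)cc(OC)cc3n2S(=O)(=O)c2cccc([N+](=O)[O-])c2)cc1` gives in this assay > 39600 nM, again a limit. Compound 3 `COc1cc(OC)c2c(=O)cc(C(=O)Nc3ccc(N4CCN(C)CC4)cc3)[nH]c2c1` gives in this assay > 19800 nM, likewise a limit rather than a measured number. Compound 3 thus stands at the limit of > 19800 nM in this assay, at which 1 of the 3 values shown sits. The other two results sit at the limit of > 39600 nM in this assay, at which 1 of the 3 values shown sits, and (the limit of > 86200 nM in this assay, at which 1 of the 3 values shown sits). With every value a limit, no order among the three compounds can be read from these results.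

Compound 4 `COc1cc(OC)c2c(=O)cc(C(=O)Nc3ccc(Oc4cccnc4)cc3)[nH]c2c1` has not yet been measured in this assay. It differs from compound 3 in one place: (pyridin-3-yl)oxy in place of 4-methylpiperazin-1-yl on an aromatic carbon, para to a large group. For the measured compounds named here, no step between measured compounds is available to guide the expectation. Every result so far is a limit, and no step beyond the scatter is expected in either direction; the most likely outcome for compound 4 is once more a limit at the top of the tested range. As a working estimate, compound 4 is expected to give in this assay about 20000 nM, with a range from 8000 nM to 50000 nM. The step this estimate implies, a step that the limit leaves unreadable from compound 3 to compound 4, is expected to stay within the scatter.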

Compound 4, half-maximal effective concentration: > 32100 nM
Compound 4: no number, only a limit; the forecaster's own chance of this, stated with the estimate: 75%; at least 1.6-fold (0.20 log units) between middle value and limit.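

For the compounds shown here, compound 3 and compound 4 both give only a limit of the assay in this assay, not a number, so no step between them can be read. The compounds shown leave open whether (pyridin-3-yl)oxy in place of 4-methylpiperazin-1-yl changes the result at all, and at what concentration any compound of the shared core reaches its half-maximal effect.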